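Swapping Selenium for Sulfur on a Quinazoline Core

The source may hold more compounds than are shown below. What is called first, only, known or untested is meant among the compounds shown, and "the series" means these compounds.

Measured so far:
Compound 1, `COc1ccc(CNc2nc([SeH])nc3ccccc23)cc1`: 60900 nM
Compound 2, `[SeH]c1nc(NCc2ccccc2)c2ccccc2n1`: > 100000 nM

Among the compounds with values here, compound 1 is the one compound that gives an actual number in a functional assay on HTB-54 cells (Homo sapiens) for cytotoxicity, read by MTT assay, with a stated time of 72 h; on this read-out lower numbers stand for stronger inhibition of growth and higher numbers for weaker inhibition of growth. Compound 2 gives only a limit in this assay, at which one of the two values sits (the limit of > 100000 nM in this assay, at which 1 of the 2 values shown sits). The step from compound 1 to compound 2, hydrogen in place of methoxy on an aromatic carbon, is recorded as an at least 1.6-fold higher number from compound 1 to compound 2 (0.21 log units; that floor lies within the scatter), and its floor lies within the usual scatter, so it says little on its own.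

Compound 3, `COc1ccc(CNc2nc(S)nc3ccccc23)cc1`, differs from compound 1 at a single atom: one sulfur atom in place of one selenium atom, on an aromatic carbon. Within the data shown here, no measured step touches this kind of change, since the one recorded step concerns the methoxy group, not the selenium. The expectation for compound 3 therefore rests only on compound 1 and on the chance that a change of a single atom leaves the number close to where it was, with a limit a real possibility.

Compound 3 is expected to give about 90000 nM in this assay, between 35000 nM and 200000 nM, a step of a 1.5-fold higher number from compound 1 to compound 3 (0.17 log units; within the scatter).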

Compound 3, concentration for total growth inhibition: 45500 nM
The estimate for compound 3 lay 2.0-fold (0.30 log units) above the measured number, and the stated range covers the measured number.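

Putting sulfanyl where selenium stood, on the aromatic carbon between two ring nitrogen atoms, is recorded in this assay as a 1.3-fold lower number from compound 1 to compound 3 (0.13 log units; within the scatter). Within the data shown here, this is the first direct look at this position, since the earlier step concerned the methoxy group, and it shows that the two compounds cannot be told apart in this assay: selenium is not required here for the growth inhibition seen with compound 1, because sulfur at the same place gives a number within the usual scatter. Compound 2 remains the only compound of the three that gives a limit and not a number, so the selenium-to-sulfur step is the only step here with a measured number at both ends: the limit of > 100000 nM in this assay, at which 1 of the 3 values shown sits.

As far as these compounds go, what an amine or a methoxy group would do at this same position stays open, since only selenium and sulfur appear there. Also open, from the compounds shown here alone, is whether sulfur and selenium would still match when hydrogen stands in place of the methoxy group, or when a longer chain joins the core.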